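This account rests on a few compounds, and the source may have more. Where it says the series, first, only, none or still open, it means among the compounds named here.

Working notes, selenocyanate series on a shared core.

Three compounds have numbers in a functional assay on A549 cells (Homo sapiens) for inhibition, read by MTT assay, with a stated time of 48 h; a higher number here means a weaker inhibitor, a lower number a stronger inhibitor. Compound 1 `COc1ccc(N(C)c2nc(C)nc3ccccc23)cc1C(=O)OCCC[Se]C#N` gives 250 nM. Compound 2 `COc1ccc(N(C)c2nc(C)nc3ccccc23)cc1OCCCCC[Se]C#N` gives 2440 nM. Compound 3 `COc1ccc(N(C)c2nc(C)nc3ccccc23)cc1C(=O)OCC[Se]C#N` gives 353 nM, the second highest of the three; its nearest neighbour is compound 1 with a 1.4-fold higher number from compound 1 to compound 3 (0.15 log units; within the scatter), its furthest compound 2 with a 6.9-fold lower number from compound 2 to compound 3 (0.84 log units; beyond the scatter).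

Compound 4 `COc1ccc(N(C)c2nc(C)nc3ccccc23)cc1OCCCCCC[Se]C#N` is not yet measured. Its difference from compound 3 is a group of 10 heavy atoms (7 carbon, 1 nitrogen, 1 oxygen, 1 selenium; no ring) in place of a group of 8 heavy atoms (4 carbon, 1 nitrogen, 2 oxygen, 1 selenium; no ring), on an aromatic carbon.

Among the measured compounds shown here, two measured steps bear on this. The step of a 6.9-fold lower number from compound 2 to compound 3 (0.84 log units; beyond the scatter) runs the same kind of exchange in reverse, an ether-linked chain giving way to an ester-linked one, and it was modest but beyond the scatter. The step of a 1.4-fold higher number from compound 1 to compound 3 (0.15 log units; within the scatter) shows that lengthening or shortening the chain by one carbon within the ester pair stayed within the scatter. Compound 4 differs from compound 2 only by one further chain carbon, so the number for compound 4 is expected to sit near that of compound 2, with 2440 nM as the anchor. The expected step is therefore upward, a 6.2-fold higher number from compound 3 to compound 4 (0.79 log units; beyond the scatter), roughly undoing the step from compound 2 to compound 3. The estimate for compound 4 in this assay is 2200 nM, with a range of 900 nM to 5500 nM.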

Compound 4, half-maximal inhibitory concentration: 5520 nM
Estimate against measurement, compound 4: 2.5-fold (0.40 log units) below; measured number outside the range, above it.
By their numbers in this assay, from the lowest: compounds 1 and 3 (each within the scatter of the next); then compound 2; then compound 4.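

In this assay, among the compounds shown here, the result separates the two linkers at this aromatic carbon more sharply than the earlier compounds did: a 16-fold higher number from compound 3 to compound 4 (1.19 log units; beyond the scatter) and a 22-fold higher number from compound 1 to compound 4 (1.34 log units; beyond the scatter) are both large steps, with the ether-linked chain of compound 4 on the high side of both ester-linked compounds. Chain length also proves to count on the ether side, where a 2.3-fold higher number from compound 2 to compound 4 (0.35 log units; beyond the scatter) lies beyond the scatter, whereas the ester pair, compounds 1 and 3, goes against any general link between chain length and a higher number. The same chain change therefore does not read alike on the two linkers: the same change on two cores in this assay, a 1.4-fold higher number (0.15 log units; within the scatter) from compound 1 to compound 3 and a 2.3-fold lower number (0.35 log units; beyond the scatter) from compound 4 to compound 2, 3.2-fold (0.50 log units) apart, beyond the scatter of two such steps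

Still open, going by these compounds, is whether the trend between compounds 2 and 4 continues with a longer chain on the ether linker, and whether an ester bearing a chain as long as that of compound 4 would stay near compounds 1 and 3. Also open, on these data alone, is how an amide linker in place of the ester, or a thiocyanate in place of the selenocyanate, would sit in this assay.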